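Compound 3 follows two compounds at a limit

This account rests on a few compounds, and the source may have more. Where it says the series, first, only, none or still open, it means among the compounds named here.

Compound 1 `COc1ccc(/C=C\c2cc(OC)c(OC)c(OC)c2)cc1OCc1ccc(CN2C[C@H](O)C[C@@H]2C(=O)O)cc1`: > 50000 nM
Compound 2 `COc1ccc(/C=C\c2cc(OC)c(OC)c(OC)c2)cc1OCc1ccc(CN2CCCC[C@@H]2C(=O)O)cc1`: > 50000 nM

Both entries come from an ADME assay on NCM460 cells (Homo sapiens) for cytotoxicity, read by CCK-8 assay, with a stated time of 48 h (a lower number here means a stronger inhibitor, a higher number a weaker inhibitor), and each is a limit of the assay, not a number. Compound 2 stands at > 50000 nM, which is a limit. Within the data shown here, the one other value, that of compound 1, is a limit too.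

Compound 3 `COc1ccc(/C=C\c2cc(OC)c(OC)c(OC)c2)cc1OCc1ccc(CN[C@H](C(=O)O)[C@H](C)O)cc1` has not yet been measured. Its difference from compound 2 is (1-carboxy-2-hydroxypropyl)amino in place of 2-carboxypiperidin-1-yl on a saturated chain carbon bound to an aromatic carbon. In words, (1-carboxy-2-hydroxypropyl)amino stands in place of 2-carboxypiperidin-1-yl on a saturated chain carbon bound to an aromatic carbon, and the entering group has no ring.

Among the measured compounds shown here, the one measured step at this place is a step that the two limits leave unreadable from compound 1 to compound 2, so it offers no size to carry over. Because of the limit of > 50000 nM in this assay, at which 2 of the 2 values shown sit, no step beyond the scatter is expected for compound 3 in this assay. The expected change is a number no higher from compound 2 to compound 3 (the limit leaves the size open). For compound 3 the estimate is 50000 nM, with an expected range from 25000 nM to 100000 nM, and a report of only a limit is the likeliest outcome.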

Compound 3, half-maximal inhibitory concentration: > 50000 nM
Compound 3 ended at the assay's limit; the forecaster's own chance of this, stated with the estimate: 85%; the middle value sits exactly at the limit.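

In this assay, compound 3 gives > 50000 nM, which is a limit of the assay. No step can be read among compound 1, compound 2 and compound 3, because all three stop at a limit: the limit of > 50000 nM in this assay, at which 3 of the 3 values shown sit.

The compounds shown leave open where each one's true half-maximal inhibitory concentration lies, and whether the groups exchanged on the saturated chain carbon make any difference to it.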